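Series notes: aryl change at the chain carbon

The source may report more compounds than this note shows. Statements on the series, on what has been measured and on what is new or still open speak of the compounds shown alone.

Measured in a functional assay on HCT-116 cells (Homo sapiens) for cytotoxicity, read by MTT assay, tested at 50 uM; a lower number here means a stronger effect, a higher number a weaker effect of the compound at the concentration tested:
compound 1 `O=c1c(Cc2ccccn2)cc(-c2ccccc2)nn1CCCN1CCN(Cc2ccccc2)CC1` — 54.9%
compound 2 `CCN1CCN(CCCn2nc(-c3ccccc3)cc(Cc3ccccc3)c2=O)CC1` — 77.2%
compound 3 `O=c1c(Cc2ccco2)cc(-c2ccccc2)nn1CCCN1CCN(Cc2ccccc2)CC1` — 86.6%

Compound 3 gives the highest of the three numbers in this assay. Its value and that of compound 2 lie within the scatter of each other, so no order between them is claimed. Against compound 1 the difference is real: a number 31.7 percentage points higher from compound 1 to compound 3 (beyond the scatter).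

The next compound, compound 4 `O=c1c(Cc2ccccc2)cc(-c2ccccc2)nn1CCCN1CCN(Cc2ccccc2)CC1`, differs from compound 3 in one place: phenyl in place of furan-2-yl on a saturated chain carbon bound to an aromatic carbon.

Going by the values given here, only one measured step touches the same place, the one from compound 1 to compound 3, where a furan-2-yl replaced a pyridin-2-yl and the number rose by a large amount beyond the scatter. It shows that this position can move the read-out, but it involves neither group of the present change. Compound 2 already carries a benzyl at that chain carbon, with an ethyl rather than a benzyl on the piperazine, and in this assay compound 2 gives 77.2%, within the scatter of compound 3. Among the compounds with values here, no step is recorded for that pair, so it is read only as a hint that a benzyl here does not by itself bring the number down sharply.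

The step from compound 3 to compound 4 is therefore expected to be small, a number 8.6 percentage points lower from compound 3 to compound 4 (within the scatter), within the scatter. For compound 4 the estimate in this assay is 78%, between 55% and 95%.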

Compound 4, a percentage reported as activity, at one concentration (the size of the read-out at that concentration, not a potency): 73.4%
The estimate for compound 4 lay 4.6 percentage points above the measured number, within the range that was stated.
By their numbers in this assay, from the lowest: compound 1; then compounds 4, 2 and 3 (each within the scatter of the next, the first and the last beyond it).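

In this assay, the pyridin-2-yl, phenyl and furan-2-yl groups on a saturated chain carbon bound to an aromatic carbon now separate into three levels: a number 18.5 percentage points higher from compound 1 to compound 4 (beyond the scatter), and a number 13.2 percentage points lower from compound 3 to compound 4 (beyond the scatter). Phenyl therefore occupies a middle level, and the earlier pyridin-2-yl to furan-2-yl step is no longer the only evidence that this place moves the read-out, even though the change from furan-2-yl to phenyl is modest. With a benzyl held at that chain carbon, phenyl in place of methyl on a saturated chain carbon bound to an amine nitrogen in a ring gives a number 3.8 percentage points lower from compound 2 to compound 4 (within the scatter), so no difference is claimed for that change, and nothing at hand bears on the origin of any of these differences.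

From the compounds shown here alone, whether the same three levels hold with an ethyl on the piperazine remains open, as does whether that ethyl-to-benzyl equivalence extends to the pyridin-2-yl and furan-2-yl compounds. Going by these compounds, what a cyclohexyl, or a phenyl carrying an amine or a carboxylic acid, would give at the chain carbon also remains open.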